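This account rests on a few compounds, and the source may have more. Where it says the series, first, only, none or still open, it means among the compounds named here.

Among the compounds with values here, the three compounds measured so far share one core. Compound 1 `CC(CCCC(=O)O)c1cccc(OCc2ccc3ccccc3n2)c1` gives 500 nM in a functional assay (lung) for inhibition, with Cavia porcellus as the target; a lower number here means a stronger inhibitor, a higher number a weaker inhibitor. Compound 2 `c1cc(CCCCc2nnn[nH]2)cc(OCc2ccc3ccccc3n2)c1` gives 105 nM in this assay, and compound 3 `CC(CCC(=O)O)Cc1cccc(OCc2ccc3ccccc3n2)c1` gives 500 nM in this assay. Compound 3 thus stands level with compound 1, the two together the highest of the three numbers; the step that separates them reads no change at the digits printed from compound 1 to compound 3 (within the scatter), whereas the other step reads a 4.8-fold higher number from compound 2 to compound 3 (0.68 log units; beyond the scatter). Compound 4 `O=C(O)CCC(Cc1cccc(OCc2ccc3ccccc3n2)c1)c1ccccc1` differs from compound 3 in one place: phenyl in place of methyl on a saturated chain carbon bound to two saturated chain carbons. Within the data shown here, no measured step exchanges an alkyl group for an aromatic ring on this chain. Among the measured compounds shown here, the only step that alters the chain while keeping the acid, no change at the digits printed from compound 1 to compound 3 (within the scatter), moves a methyl along it and leaves the number unchanged, and the two steps that do move the number, a 4.8-fold lower number from compound 1 to compound 2 (0.68 log units; beyond the scatter) and a 4.8-fold higher number from compound 2 to compound 3 (0.68 log units; beyond the scatter), exchange the acid for a tetrazole and not the methyl. The data therefore give no ground for a large step in this assay in either direction, and the expected change is a 1.3-fold lower number from compound 3 to compound 4 (0.10 log units; within the scatter). For compound 4 the expected value in this assay is 400 nM, with a range from 100 nM to 1600 nM.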

Compound 4, half-maximal inhibitory concentration: 56 nM
Compound 4: middle estimate off by 7.1-fold (0.85 log units), on the high side, outside the stated range (below it).
By their numbers in this assay, from the lowest: compounds 4 and 2 (each within the scatter of the next); then compounds 1 and 3 (each within the scatter of the next).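

On the saturated chain carbon bound to two saturated chain carbons, phenyl in place of methyl gives an 8.9-fold lower number from compound 3 to compound 4 (0.95 log units; beyond the scatter) in this assay and so shows that this part of the chain can move the number with the carboxylic acid kept in place. Within the data shown here, the earlier chain step, no change at the digits printed from compound 1 to compound 3 (within the scatter), only moved a methyl along the chain, and the steps beyond the scatter exchanged the acid and the tetrazole, so the earlier compounds gave no sign that the substituent on this carbon matters. Nothing at hand bears on why the exchange of methyl for phenyl lowers the number.

The compounds shown leave open whether the drop belongs to the six-membered aromatic ring itself or to the larger group on this carbon, a question that a cyclohexyl, an ethyl or a benzyl group on the same carbon would address. They also leave open whether a tetrazole in place of the carboxylic acid of compound 4 would lower the number further or leave it where it stands.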